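The compounds below may be only part of what the source reports. "The series", "measured", "known", "first", "only" and "open" are said of these compounds alone.

Measured so far, in a functional assay on HL-60 cells (Homo sapiens) for inhibition, read by sulforhodamine B assay, with a stated time of 48 h, tested at 10 uM; a lower number here means less inhibition, a higher number more inhibition at the concentration tested (going by the name of the read-out):
compound 1, `COc1ccc(-c2cn3ccnc3c(-c3ccc4ncn(C5CCCCC5)c4c3)n2)cc1`, gives 98.6%
compound 2, `Fc1ccc(-c2cn3ccnc3c(-c3ccc4ncn(C5CCCCC5)c4c3)n2)cc1`, gives 2.03%
compound 3, `COc1ccccc1-c1cn2ccnc2c(-c2ccc3ncn(C4CCCCC4)c3c2)n1`, gives 14.6%

All three share one core and differ only in the phenyl group that sits on it. From compound 1 to compound 2 the change is fluoro in place of methoxy on an aromatic carbon, and it made a step of a number 96.6 percentage points lower from compound 1 to compound 2 (beyond the scatter). From compound 1 to compound 3 the difference is 2-methoxyphenyl in place of 4-methoxyphenyl on an aromatic carbon, with a step of a number 84 percentage points lower from compound 1 to compound 3 (beyond the scatter). Compound 3 stands second of the three, with a number 12.6 percentage points higher from compound 2 to compound 3 (beyond the scatter) separating it from compound 2.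

Compound 4, `Fc1ccccc1-c1cn2ccnc2c(-c2ccc3ncn(C4CCCCC4)c3c2)n1`, is not yet measured. It differs from compound 3 by fluoro in place of methoxy on an aromatic carbon. For the measured compounds named here, this is the same kind of change as the one from compound 1 to compound 2, not the same: there the fluoro sat para to a large group, here it sits ortho to a large group. Since compound 3 already gives 14.6%, there is little room for a drop of the earlier size. Compound 4 is expected to move by a number 9.6 percentage points lower from compound 3 to compound 4 (within the scatter) in this assay, because compound 3 starts at 14.6%. The estimate for compound 4 is 5%, likely between 0% and 20%.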

Compound 4, a percentage reported as inhibition, at one concentration (the size of the read-out at that concentration, not a potency): 9.3%
Estimate against measurement, compound 4: 4.3 percentage points below; low and high end bracket the measured number.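

In this assay, fluoro in place of methoxy did not carry over at equal size from the 4-methoxyphenyl setting to the 2-methoxyphenyl setting: the same change on two cores in this assay, a number 96.6 percentage points lower (beyond the scatter) from compound 1 to compound 2 and a number 5.3 percentage points lower (within the scatter) from compound 3 to compound 4, 91.3 percentage points apart, beyond the scatter of two such steps

This does not show that the change is harmless on the second core. Compound 3 already gives 14.6%, so there was little room for a fall, and the result is a step of a number 5.3 percentage points lower from compound 3 to compound 4 (within the scatter). For the compounds shown here, the two fluoro compounds cannot be told apart, with a step of a number 7.3 percentage points higher from compound 2 to compound 4 (within the scatter), whereas a step of a number 89.3 percentage points lower from compound 1 to compound 4 (beyond the scatter) leaves compound 1 as the one clear high value among the four, so the comparison rests on a single high point.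

Going by these compounds, whether that high value belongs to methoxy in that one place, or would also appear with ethoxy, a longer alkoxy chain or an amine there, stays open. A read-out at one concentration also gives no potency for any of these compounds.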